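The source may hold more compounds than are shown below. What is called first, only, known or untested is meant among the compounds shown, and "the series" means these compounds.

Measured in a functional assay on MCF7 cells (Homo sapiens) for inhibition, read by fluorescence, with a stated time of 72 h; on this read-out higher numbers stand for weaker inhibition and lower numbers for stronger inhibition:
- compound 1 `CC(C)n1cnc2c(NC(=N)N)nc(N)nc21`: 97200 nM
- compound 2 `CC[C@H](CO)Nc1nc(NC(=N)N)c2ncn(C(C)C)c2n1`: 4500 nM
- compound 3 `CC(C)[C@H](CO)Nc1nc(NC(=N)N)c2ncn(C(C)C)c2n1`: 10500 nM

Of these three numbers, compound 3 holds the second highest, with compound 2 lower and compound 1 higher. Compound 4 `CC(C)n1cnc2c(NC(=N)N)nc(N3CCC[C@H]3CO)nc21` differs from compound 3 in one place: 2-(hydroxymethyl)pyrrolidin-1-yl in place of (1-(hydroxymethyl)-2-methylpropyl)amino on an aromatic carbon, (2-(hydroxymethyl)pyrrolidin-1-yl in place of (1-(hydroxymethyl)-2-methylpropyl)amino on an aromatic carbon).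

Two measured steps show that a substituent on this nitrogen matters: the large 22-fold lower number from compound 1 to compound 2 (1.33 log units; beyond the scatter) and the modest 9.3-fold lower number from compound 1 to compound 3 (0.97 log units; beyond the scatter). Changing the chain itself moved the number less, with the modest 2.3-fold higher number from compound 2 to compound 3 (0.37 log units; beyond the scatter). Among the measured compounds shown here, no measured step shows a ring in this place, so the direction remains open. A small step in this assay is therefore expected, possibly none beyond the scatter. The estimated step is a 1.1-fold lower number from compound 3 to compound 4 (0.02 log units; within the scatter). For compound 4 the expected value is 10000 nM, with an estimated range from 3000 nM to 35000 nM.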

Compound 4, half-maximal inhibitory concentration: 6200 nM
Beside the measured number, compound 4's estimate is 1.6-fold (0.21 log units) above it; measured number inside the range.
By their numbers in this assay, from the lowest: compounds 2, 4 and 3 (each within the scatter of the next, the first and the last beyond it); then compound 1.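

In this assay, the 2-(hydroxymethyl)pyrrolidin-1-yl group brings a five-membered non-aromatic ring to this aromatic carbon and has one hydrogen-bond donor fewer than the open chain it replaces, yet the result is a 1.7-fold lower number from compound 3 to compound 4 (0.23 log units; within the scatter) and, against the shorter chain, a 1.4-fold higher number from compound 2 to compound 4 (0.14 log units; within the scatter). A ring on this nitrogen therefore keeps the number level with both open chains, and the hydrogen on that nitrogen in compound 2 and compound 3 is not required for this. The benefit of substitution also extends to a ring, with a 16-fold lower number from compound 1 to compound 4 (1.20 log units; beyond the scatter) and no measurement here gives a reason for any of these results.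

From the compounds shown here alone, it remains open whether the hydroxymethyl group is needed, as a plain pyrrolidine would show. Nor do these compounds tell how a six-membered piperidine ring or a longer chain ending in a carboxylic acid would behave here.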